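This account rests on a few compounds, and the source may have more. Where it says the series, first, only, none or still open, it means among the compounds named here.

Measured set:
compound 1 `O=C(Nc1ccccn1)c1c(O)c2cccnc2n(-c2ccccc2)c1=O`, -13.5%
compound 2 `O=C(Nc1ccc([N+](=O)[O-])cc1)c1c(O)c2cccnc2n(-c2ccccc2)c1=O`, -7.6%
compound 3 `O=C(Nc1cnccn1)c1c(O)c2cccnc2n(-c2ccccc2)c1=O`, 29.6%

All three values come from a functional assay on the whole organism for inhibition, with Rattus norvegicus as the target, read by paw edema, at a dose of 100 mg/kg by the oral route; a lower number here means less inhibition, a higher number more inhibition at the dose given (going by the name of the read-out). Compound 2 sits with compound 1 inside the scatter, the gap being a number 5.9 percentage points higher from compound 1 to compound 2 (within the scatter), and well apart from compound 3, that gap being a number 37.2 percentage points higher from compound 2 to compound 3 (beyond the scatter). The next compound, compound 4 `Cc1cnccc1NC(=O)c1c(O)c2cccnc2n(-c2ccccc2)c1=O`, differs from compound 2 by 3-methylpyridin-4-yl in place of 4-nitrophenyl on an amide-type nitrogen. The step bearing on it most directly is a number 37.2 percentage points higher from compound 2 to compound 3 (beyond the scatter), a heteroaryl entering in place of 4-nitrophenyl, which was large; but a number 43.1 percentage points higher from compound 1 to compound 3 (beyond the scatter) shows two heteroaryls on the same nitrogen can lie far apart, so the direction is uncertain. A modest upward step is expected, a number 15.6 percentage points higher from compound 2 to compound 4 (beyond the scatter). Compound 4 is estimated at 8%, within -20% to 35%.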

Compound 4, a percentage reported as inhibition, in the whole organism at one dose (the size of the read-out at that dose, not a potency): 26.9%
Estimate against measurement, compound 4: 18.9 percentage points below; low and high end bracket the measured number.
By their numbers in this assay, from the lowest: compounds 1 and 2 (each within the scatter of the next); then compounds 4 and 3 (each within the scatter of the next).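

Replacing 4-nitrophenyl with 3-methylpyridin-4-yl on the amide-type nitrogen gives a large gain in this assay (a number 34.5 percentage points higher from compound 2 to compound 4 (beyond the scatter)), so pyrazin-2-yl is no longer the only heteroaryl to separate from 4-nitrophenyl, and 3-methylpyridin-4-yl cannot be told apart from it (a number 2.7 percentage points lower from compound 3 to compound 4 (within the scatter)). Pyridin-2-yl goes against any rule that a heteroaryl alone suffices (a number 40.4 percentage points higher from compound 1 to compound 4 (beyond the scatter)). Nothing measured here gives a reason for these steps.

Open, on these data alone, is what the methyl group adds, which plain pyridin-4-yl would show. Also open, as far as these compounds go, is whether a saturated amine such as a piperidine ring on the same nitrogen keeps the read-out.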